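The source may report more compounds than this note shows. Statements on the series, on what has been measured and on what is new or still open speak of the compounds shown alone.

Compound 1 `O=C(Nc1cccc(-n2cc(-c3ccncc3)c(-c3ccc(Cl)c(O)c3)n2)c1)Nc1cccc(C(F)(F)F)c1`: 9820 nM
Compound 2 `COc1cc(-c2nn(-c3cccc(NC(=O)Nc4cc(C(F)(F)F)cc(C(F)(F)F)c4)c3)cc2-c2ccncc2)ccc1Cl`: 702 nM
Compound 3 `COc1cc(-c2nn(-c3cccc(NC(=O)Nc4cccc(C(F)(F)F)c4)c3)cc2-c2ccncc2)ccc1Cl`: 748 nM

All three compounds share one core and were tested in a functional assay on HT-29 cells (Homo sapiens) for inhibition, read by sulforhodamine B assay, with a stated time of 48 h; a lower number here means a stronger inhibitor of growth, a higher number a weaker inhibitor of growth. Compound 2 gives the lowest number of the three, yet its nearest neighbour is within the scatter: a 1.1-fold higher number from compound 2 to compound 3 (0.03 log units; within the scatter). The furthest is compound 1, and compound 1 gives 9820 nM, where compound 2 gives 702 nM. Among the compounds with values here, the one measured step that separates a large gap from a small one is a 13-fold lower number from compound 1 to compound 3 (1.12 log units; beyond the scatter).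

Compound 4 `O=C(Nc1cccc(-n2cc(-c3ccncc3)c(-c3ccc(Cl)c(O)c3)n2)c1)Nc1cc(C(F)(F)F)cc(C(F)(F)F)c1` is the next compound in line. It differs from compound 2 in one place: hydrogen in place of methyl on an oxygen on an aromatic ring. This is the same change as that between compound 1 and compound 3, only run backwards. Within the data shown here, two measured steps bear on it. The first, a 13-fold lower number from compound 1 to compound 3 (1.12 log units; beyond the scatter), is large and beyond the scatter, and reversing it points to a large rise in the number. The second, a 1.1-fold higher number from compound 2 to compound 3 (0.03 log units; within the scatter), shows that the extra trifluoromethyl on the second aromatic ring does not move the number, so compound 4 should land close to compound 1, which differs from it only in that trifluoromethyl. Compound 4 is therefore expected to give a much higher number than compound 2 in this assay, a step estimated at a 13-fold higher number from compound 2 to compound 4 (1.11 log units; beyond the scatter). For compound 4 the estimate is 9000 nM, with a range from 3000 nM to 30000 nM.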

Compound 4, concentration for 50% growth inhibition: 746 nM
Estimate against measurement, compound 4: 12-fold (1.08 log units) above, and the stated range ends above it.
By their numbers in this assay, from the lowest: compounds 2, 4 and 3 (each within the scatter of the next); then compound 1.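

In this assay, putting hydrogen in place of methyl on that oxygen now gives a 1.1-fold higher number from compound 2 to compound 4 (0.03 log units; within the scatter), so the change from methoxy to hydroxy has no single size, and its size differs with the presence of the extra trifluoromethyl: the same change on two cores in this assay, a 13-fold lower number (1.12 log units; beyond the scatter) from compound 1 to compound 3 and a 1.1-fold lower number (0.03 log units; within the scatter) from compound 4 to compound 2, 12-fold (1.09 log units) apart, beyond the scatter of two such steps

Read the other way, adding that trifluoromethyl to the hydroxy compound gives a 13-fold lower number from compound 1 to compound 4 (1.12 log units; beyond the scatter), although adding it to the methoxy compound moved the number within the scatter only: the same change on two cores in this assay, a 1.1-fold higher number (0.03 log units; within the scatter) from compound 2 to compound 3 and a 13-fold higher number (1.12 log units; beyond the scatter) from compound 4 to compound 1, 12-fold (1.09 log units) apart, beyond the scatter of two such steps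

Of the four compounds, only compound 1, which carries neither the methoxy nor the extra trifluoromethyl, stands clearly apart, while compound 3 with only the methoxy, compound 4 with only the extra trifluoromethyl and compound 2 with both all lie within the scatter of one another.

The compounds shown do not explain why either group can make up for the absence of the other. As far as these compounds go, it also remains open whether an ethyl or a longer chain on that oxygen, an amine on the same aromatic carbon, or a nitrile in place of the extra trifluoromethyl would follow the same pattern.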